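Swapping Methoxy for Hydroxyoxetane: Expected Clearance of Compound 4

This account rests on a few compounds, and the source may have more. Where it says the series, first, only, none or still open, it means among the compounds named here.

Compound 1, `CC(C)(C)c1ccc(C(=O)NCc2ccc(NS(C)(=O)=O)cc2F)cc1`, gives 47 mL.min-1.g-1 in an ADME assay on microsomes from liver (Rattus norvegicus, strain Sprague-Dawley) for metabolic stability, read by HPLC, using NADPH, with stated times of 5 min and 60 min, tested at 10 uM; on this read-out higher numbers stand for fast clearance and lower numbers for slow clearance.
Compound 2, `CC(C)(C)c1ccc(C(=O)NCc2c(Cl)cc(NS(C)(=O)=O)cc2Cl)cc1`, gives 16 mL.min-1.g-1.
Compound 3, `COc1ccc(C(=O)NCc2ccc(NS(C)(=O)=O)cc2Cl)cc1`, gives 5 mL.min-1.g-1.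

Of these three, compound 3 shows the lowest intrinsic clearance; compound 2 stands nearest and compound 1 furthest, and both gaps lie beyond the usual scatter. Compound 4, `CS(=O)(=O)Nc1ccc(CNC(=O)c2ccc(C3(O)COC3)cc2)c(Cl)c1`, differs from compound 3 in one place: 3-hydroxyoxetan-3-yl in place of methoxy on an aromatic carbon. Going by the values given here, no pair of measured compounds carries this change, so there is no measured step to lean on. In this assay a small step, toward slower clearance or none beyond the scatter, is expected because compound 3 already sits at 5 mL.min-1.g-1. Compound 4 is therefore estimated at 4 mL.min-1.g-1, with a range from 1.5 mL.min-1.g-1 to 10 mL.min-1.g-1. The expected step is a 1.3-fold lower number from compound 3 to compound 4 (0.10 log units; within the scatter).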

Compound 4, intrinsic clearance in microsomes: 5.4 mL.min-1.g-1
For compound 4 the middle estimate is 1.4-fold (0.13 log units) below the measured one, and the stated range covers the measured number.
By their numbers in this assay, from the lowest: compounds 3 and 4 (each within the scatter of the next); then compound 2; then compound 1.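

In this assay, 3-hydroxyoxetan-3-yl can stand in place of methoxy, para to a large group, and the number stays within the scatter (a 1.1-fold higher number from compound 3 to compound 4 (0.03 log units; within the scatter)). So a larger group, which brings a four-membered ring and a hydrogen-bond donor, is tolerated here without a clear shift in clearance. Nothing measured here explains why the two groups read alike.

Still open, as far as these compounds go, is how other groups at this position, such as an amine or a carboxylic acid, would read. Also open, from the compounds shown here alone, is whether this swap would behave the same way on a different core.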